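The source may hold more compounds than are shown below. What is called first, only, known or untested is meant among the compounds shown, and "the series" means these compounds.

Two measured compounds share one core and differ in a single group. Compound 1 `COc1ccc(N2COc3ccc(C(=O)/C=C/c4ccccc4Cl)cc3C2)cc1` carries a methoxy group, and in a functional assay on the whole organism (strain Wistar) for inhibition, with Rattus norvegicus as the target, read by paw edema, with a stated time of 3 h, at a dose of 20 mg/kg by the oral route (a higher number here means more inhibition at the dose given (going by the name of the read-out), a lower number less inhibition), compound 1 gives 63.4%. Compound 2 `Cc1ccc(N2COc3ccc(C(=O)/C=C/c4ccccc4Cl)cc3C2)cc1` carries a methyl group in place of that methoxy, and in this assay compound 2 gives 60.4%. The step of a number 3 percentage points lower from compound 1 to compound 2 (within the scatter) stays within the scatter, so the two numbers cannot be told apart; compound 2 stands beside compound 1 rather than apart from it.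

Compound 3 `Cc1ccc(N2COc3ccc(C(=O)/C=C/c4ccc(Cl)cc4Cl)cc3C2)cc1` has not yet been measured. It differs from compound 2 by chloro in place of hydrogen on an aromatic carbon. Within the data shown here, no measured step involves a chloro group entering anywhere; the only known step concerns methyl in place of methoxy, and that step was small. The data therefore give no reason to expect movement in either direction, and the expectation for compound 3 is a number close to that of compound 2, with an expected step of a number 0.4 percentage points lower from compound 2 to compound 3 (within the scatter) that remains within the scatter. The estimate for compound 3 in this assay is 60%, with a range from 45% to 75%.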

Compound 3, a percentage reported as inhibition, in the whole organism at one dose (the size of the read-out at that dose, not a potency): 71.9%
Compound 3: the middle estimate sits 11.9 percentage points below what was measured; the measured number falls inside the stated range.
By their numbers in this assay, from the lowest: compounds 2, 1 and 3 (each within the scatter of the next, the first and the last beyond it).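

In this assay, among these compounds, the change from 2-chlorophenyl to 2,4-dichlorophenyl gives a number 11.5 percentage points higher from compound 2 to compound 3 (beyond the scatter), and this modest rise is the first step to lie beyond the scatter. The earlier swap of methoxy for methyl, a number 3 percentage points lower from compound 1 to compound 2 (within the scatter), could not be told from noise, so the new chloro shows that the position para to a large group and meta to a chloro group is one where adding a single atom can visibly shift the read-out at this dose. The compounds shown offer no measurement that could explain the rise, so the data record the shift but not its cause.

From the compounds shown here alone, it remains open whether the rise is specific to chloro or would also appear with another group at this position, such as fluoro, nitro or a dimethylamino group. It is also unclear whether the same chloro would bring a similar rise to the methoxy compound, and since this read-out reports the effect at one dose, it says nothing about how the effect changes with dose.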